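A few compounds are considered here, and "the series" means these few. Any claim that something is new, unique, unknown or untested is made for them only; others in the source may bear on it.

Measured so far in a functional assay on ileum (Cavia porcellus) for inhibition of Polyunsaturated fatty acid 5-lipoxygenase (Homo sapiens); on this read-out higher numbers stand for weaker inhibition and lower numbers for stronger inhibition:

compound 1 `Cc1c(C)c2c(c(C)c1O)SCO2`, 290 nM
compound 2 `CCCC1Oc2c(C)c(C)c(O)c(C)c2S1`, 25 nM
compound 3 `CCCCCCCC1Oc2c(C)c(C)c(O)c(C)c2S1`, 220 nM

Compound 2 stands lowest of the three; its nearest neighbour is compound 3 and the furthest is compound 1, both steps beyond the scatter. The open question is compound 4 `Cc1c(C)c2c(c(C)c1O)SC(CCC(N)=O)O2`, which differs from compound 2 by carbamoyl in place of methyl on a saturated chain carbon, two bonds along the chain from a saturated ring carbon. For the measured compounds named here, two steps touch the saturated ring substituent: a 12-fold lower number from compound 1 to compound 2 (1.06 log units; beyond the scatter) and an 8.8-fold higher number from compound 2 to compound 3 (0.94 log units; beyond the scatter). Neither introduces a donor or acceptor, so the bearing of a carbamoyl is uncertain; the chain grows by two heavy atoms, as in the loss seen from compound 2 to compound 3, though far less. A step in this assay of a 3.2-fold higher number from compound 2 to compound 4 (0.51 log units; beyond the scatter) is therefore expected, toward a higher number. Compound 4 is estimated at 80 nM, within 25 nM to 300 nM.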

Compound 4, half-maximal inhibitory concentration: 520 nM
Compound 4: middle estimate off by 6.5-fold (0.81 log units), on the low side; measured number outside the range, above it.
By their numbers in this assay, from the lowest: compound 2; then compounds 3, 1 and 4 (each within the scatter of the next, the first and the last beyond it).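

In this assay, carbamoyl in place of methyl on a saturated chain carbon, two bonds along the chain from a saturated ring carbon, gives a 21-fold higher number from compound 2 to compound 4 (1.32 log units; beyond the scatter), so the chain end is sensitive to this change even at a short length. With 2-carbamoylethyl added to the core of compound 1, the result is a 1.8-fold higher number from compound 1 to compound 4 (0.25 log units; within the scatter), so the gain seen with propyl does not carry over, and carbamoyl in place of pentyl gives a 2.4-fold higher number from compound 3 to compound 4 (0.37 log units; beyond the scatter). No measurement here accounts for these steps. Open, on these data alone, is whether a carboxylic acid, a nitrile or a hydroxyl at the chain end behaves like carbamoyl. Also open, as far as these compounds go, is how a butyl chain at the same saturated ring carbon compares with propyl.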